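From 3-chlorophenyl to 2-bromophenyl on a shared core

The compounds below may be only part of what the source reports. "The series", "measured", "known", "first", "only" and "open" are said of these compounds alone.

For the measured compounds named here, in a functional assay on MDA-MB-231 cells (Homo sapiens) for antiproliferative activity, read by MTT assay, with a stated time of 72 h (on this read-out higher numbers stand for weaker inhibition and lower numbers for stronger inhibition), compound 1 (`CC(C)(C)c1ccc(OCCCON2C(N)=NC(N)=NC23CCSCC3)cc1`) gives 1 nM and compound 3 (`NC1=NC2(CCOCC2)N(OCCCOc2ccccc2Br)C(N)=N1`) gives 910 nM as the lowest and highest of the three numbers so far. Compound 2 (`NC1=NC2(CCSCC2)N(OCCCOc2cccc(Cl)c2)C(N)=N1`) stands in the middle at 130 nM as the second highest, and its gaps to both others lie beyond the usual scatter. Compound 4 (`NC1=NC2(CCSCC2)N(OCCCOc2ccccc2Br)C(N)=N1`) has not yet been measured. It keeps the core of compound 2 and carries 2-bromophenyl in place of 3-chlorophenyl on an oxygen on a saturated carbon. Going by the values given here, no measured pair shows this change alone, so its size can only be judged indirectly. The 2-bromophenyl group also appears on compound 3, which at 910 nM reads higher than compound 2, but compound 3 has a different core. In this assay the expected step is small and towards a higher number (a 1.7-fold higher number from compound 2 to compound 4 (0.23 log units; within the scatter)) and may not pass the scatter. Among the compounds with values here, for compound 4 the estimated value is 220 nM with an expected range from 50 nM to 900 nM given the wide spread of the numbers so far.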

Compound 4, half-maximal inhibitory concentration: 10 nM
Beside the measured number, compound 4's estimate is 22-fold (1.34 log units) above it; the measured number lies below the stated range.
By their numbers in this assay, from the lowest: compound 1; then compound 4; then compound 2; then compound 3.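

For the compounds shown here, exchanging 3-chlorophenyl for 2-bromophenyl on the shared core in this assay gives a 13-fold lower number from compound 2 to compound 4 (1.11 log units; beyond the scatter), so this position responds strongly to the change, which no earlier pair could show. The 2-bromophenyl group also has no fixed effect on the number: compound 3 gives 910 nM with it, while compound 4, with a different core, gives 10 nM. The data offered here contain nothing that accounts for the size of this step.

The change alters both the halogen and where it sits on the phenyl ring, and the compounds shown leave open which of the two matters. As far as these compounds go, a 2-chlorophenyl or 3-bromophenyl group on the same core would separate them, and it also remains open whether the step would recur on the core of compound 3.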